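This account rests on a few compounds, and the source may have more. Where it says the series, first, only, none or still open, it means among the compounds named here.

Measured so far:
Compound 1 `COc1cc(-c2cc(/C=C/C(=O)c3ccc(N)cc3)[nH]n2)cc(OC)c1OC` gives 1% in a functional assay on PC-3 cells (Homo sapiens) for cytotoxicity, read by sulforhodamine B assay, with a stated time of 48 h, tested at 10 uM; on this read-out lower numbers stand for a stronger effect and higher numbers for a weaker effect at the one concentration tested.
Compound 2 `COc1ccc(C(=O)/C=C/c2cc(-c3cc(OC)c(OC)c(OC)c3)n[nH]2)cc1` gives -68% in this assay.

For the measured compounds named here, compound 1 stands highest of the two numbers; its only neighbour is compound 2, reached by a number 69 percentage points lower from compound 1 to compound 2 (beyond the scatter). Compound 3 `COc1ccc(-c2cc(/C=C/C(=O)c3ccc(N)cc3)[nH]n2)cc1OC` differs from compound 1 by hydrogen in place of methoxy on an aromatic carbon. Going by the values given here, no measured step shows what this removal of a methoxy does: the one step known, a number 69 percentage points lower from compound 1 to compound 2 (beyond the scatter), concerns a different change and gives no guide here. With nothing to lean on, the change is taken as roughly neutral. Compound 3 is therefore expected to show a number 9 percentage points higher from compound 1 to compound 3 (within the scatter), an estimated 10%, within -45% to 60%.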

Compound 3, a percentage reported as activity, at one concentration (the size of the read-out at that concentration, not a potency): 20%
Compound 3: the middle estimate sits 10 percentage points below what was measured; measured number inside the range.
By their numbers in this assay, from the lowest: compound 2; then compound 1; then compound 3.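

Replacing this methoxy with hydrogen in this assay gives a number 19 percentage points higher from compound 1 to compound 3 (beyond the scatter), showing that this position on the aromatic ring is not silent. Since lower numbers stand for a stronger effect, losing this one methoxy weakens the effect on this read-out. Nothing available accounts for the shift.

The compounds shown leave open whether another group at this place, such as a hydroxy group, a fluorine atom or an ethoxy group, would restore or strengthen the effect. They also leave open whether methoxy in place of amino on the other aromatic ring would lower the number on the core of compound 3.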